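The source may hold more compounds than are shown below. What is called first, only, known or untested is meant among the compounds shown, and "the series" means these compounds.

Measured compounds:
compound 1, `C=C(Br)C(=O)Nc1ccc(C(=O)/C=C/c2cccc(OC)c2)cc1`, 1100 nM
compound 2, `C=C(Br)C(=O)Nc1ccc(C(=O)/C=C/c2ccccc2OC)cc1`, 240 nM
compound 3, `C=C(Br)C(=O)Nc1ccc(C(=O)/C=C/c2ccc(OC)cc2OC)cc1`, 1500 nM

All three were run in a functional assay on MOLT-4 cells (Homo sapiens) for antiproliferative activity, with a stated time of 48 h; on this read-out higher numbers stand for weaker inhibition and lower numbers for stronger inhibition. Compound 1 and compound 2 hold the same atoms joined differently: 3-methoxyphenyl in place of 2-methoxyphenyl on a double-bonded chain carbon bound to a double-bonded chain carbon. Across this pair the read-out moves a 4.6-fold lower number from compound 1 to compound 2 (0.66 log units; beyond the scatter). Compound 3 carries one group more than compound 2, (methoxy in place of hydrogen on an aromatic carbon), and this gives a 6.3-fold higher number from compound 2 to compound 3 (0.80 log units; beyond the scatter). Compound 1 and compound 3 lie within the scatter of each other, so no order between them is claimed.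

Compound 4, `C=C(Br)C(=O)Nc1ccc(C(=O)/C=C/c2cc(OC)cc(OC)c2)cc1`, awaits measurement in this assay. Relative to compound 1 it shows (methoxy in place of hydrogen on an aromatic carbon). This is the same kind of change as that from compound 2 to compound 3, but not the same: in compound 3 the entering methoxy is para to a large group, in compound 4 it is meta to a large group; in both it is meta to a methoxy group. Resting on the step of a 6.3-fold higher number from compound 2 to compound 3 (0.80 log units; beyond the scatter) and on compound 1 at 1100 nM, compound 4 is expected at 3500 nM. The expected step of a 3.2-fold higher number from compound 1 to compound 4 (0.50 log units; beyond the scatter) points the same way as the earlier one, with less certainty given the different place. Compound 4 is estimated to fall between 1200 nM and 10000 nM.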

Compound 4, half-maximal inhibitory concentration: 1500 nM
The estimate for compound 4 lay 2.3-fold (0.37 log units) above the measured number; low and high end bracket the measured number.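

On the core of compound 1, methoxy in place of hydrogen on an aromatic carbon gives a 1.4-fold higher number from compound 1 to compound 4 (0.13 log units; within the scatter), so in this assay no change can be read from this step. The size of the step does not carry over between the two cores, and a value for one cannot be taken as a reliable guide to the other: the same change on two cores in this assay, a 6.3-fold higher number (0.80 log units; beyond the scatter) from compound 2 to compound 3 and a 1.4-fold higher number (0.13 log units; within the scatter) from compound 1 to compound 4, 4.6-fold (0.66 log units) apart, beyond the scatter of two such steps The two pairs differ both in the core and in the place of the entering methoxy, so they show neither which of the two sets the gap nor any reason for it.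

Still open, going by these compounds, is whether a second pair with the entering methoxy at one matching place on both cores would give steps of similar size. Also open, on these data alone, is how a hydroxy group or an amine at these same places on the ring would compare with methoxy, and whether such a replacement would show the same dependence on the core.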